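The compounds below may be only part of what the source reports. "The series", "measured", "known", "first", "only" and "open" are said of these compounds alone.

Series in an ADME assay on MT4 cells (Homo sapiens) for cytotoxicity, read by MTT assay (a lower number here means that less compound is tolerated, a higher number that more compound is tolerated), measured so far:
Compound 1 `Cc1ccc(N(C(=O)c2cccc([N+](=O)[O-])c2)C(=S)OCCN2C(=O)c3ccccc3C2=O)cc1`: 100000 nM
Compound 2 `Cc1ccc(N(C(=O)c2c(F)cccc2F)C(=S)OCCN2C(=O)c3ccccc3C2=O)cc1`: 65000 nM
Compound 3 `Cc1ccc(N(C(=O)c2c(Cl)cccc2Cl)C(=S)OCCN2C(=O)c3ccccc3C2=O)cc1`: 22000 nM

Compound 3 stands lowest of the three at 22000 nM, with compound 2 its nearest neighbour and compound 1 the furthest. The next structure, compound 4 `COc1cccc(OC)c1C(=O)N(C(=S)OCCN1C(=O)c2ccccc2C1=O)c1ccc(C)cc1`, differs from it at one place: 2,6-dimethoxyphenyl in place of 2,6-dichlorophenyl on a carbonyl carbon. In words, this is 2,6-dimethoxyphenyl in place of 2,6-dichlorophenyl on a carbonyl carbon.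

Going by the values given here, all the measured steps fall at this same place. They are a 1.5-fold lower number from compound 1 to compound 2 (0.19 log units; within the scatter), a 4.5-fold lower number from compound 1 to compound 3 (0.66 log units; beyond the scatter) and a 3.0-fold lower number from compound 2 to compound 3 (0.47 log units; beyond the scatter). The first lies within the scatter, while the other two are modest. None of them involves 2,6-dimethoxyphenyl, so the data give no direct reading for this group. Both of the other groups tested gave higher numbers than 2,6-dichlorophenyl, as the step of a 3.0-fold lower number from compound 2 to compound 3 (0.47 log units; beyond the scatter) shows, and this supports a modest upward expectation in this assay rather than a further fall. The expected change is a 2.0-fold higher number from compound 3 to compound 4 (0.31 log units; beyond the scatter), and it is an uncertain estimate that could still end within the scatter. For compound 4 the estimated value is 45000 nM, with an expected range of 18000 nM to 110000 nM.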

Compound 4, half-maximal cytotoxic concentration: 36000 nM
Compound 4: middle estimate off by 1.3-fold (0.10 log units), on the high side; low and high end bracket the measured number.
By their numbers in this assay, from the lowest: compounds 3, 4, 2 and 1 (each within the scatter of the next, the first and the last beyond it).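

In this assay, replacing 2,6-dichlorophenyl with 2,6-dimethoxyphenyl on this carbonyl carbon gives a step within the scatter (a 1.6-fold higher number from compound 3 to compound 4 (0.21 log units; within the scatter)), and replacing 2,6-difluorophenyl with it does the same (a 1.8-fold lower number from compound 2 to compound 4 (0.26 log units; within the scatter)), so compound 4 cannot be ordered against either compound 3 or compound 2, even though those two are separated from each other (a 3.0-fold lower number from compound 2 to compound 3 (0.47 log units; beyond the scatter)). Going by these compounds alone, exchanging chlorine-bearing for oxygen-bearing substituents, with hydrogen-bond acceptors entering where the leaving group had none, therefore produces no step beyond the scatter at this position, while the only new step beyond it is the modest one from the 3-nitrophenyl group (a 2.8-fold lower number from compound 1 to compound 4 (0.44 log units; beyond the scatter)). No measurement on hand accounts for any of these steps.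

Still open, as far as these compounds go, is whether a plain phenyl group, or a phenyl group carrying an amine or a carboxylic acid, would fall within this narrow range of numbers or leave it. Also open, from the compounds shown here alone, is whether the modest spread seen here would hold on a core altered away from this carbonyl carbon, for example with a longer chain in the shared core.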